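Removing an aromatic methyl: what compound 4 may show

The source may hold more compounds than are shown below. What is called first, only, known or untested is meant among the compounds shown, and "the series" means these compounds.

Compound 1 `CC(C)=CCC/C(C)=C/CC/C(C)=C/CC[C@]1(C)CCc2c(C)c(OC(=O)NS(=O)(=O)c3ccc(C)cc3)c(C)c(C)c2O1`: > 10000 nM
Compound 2 `CC(C)=CCC/C(C)=C/CC/C(C)=C/CC[C@]1(C)CCc2c(C)c(OC(=O)NS(=O)(=O)c3ccccc3)c(C)c(C)c2O1`: > 10000 nM
Compound 3 `CC(C)=CCC/C(C)=C/CC/C(C)=C/CC[C@]1(C)CCc2cc(OC(=O)NS(=O)(=O)c3ccc(Cl)cc3)c(C)c(C)c2O1`: > 10000 nM

Three compounds were tested in a functional assay on MDA-MB-231 cells (Homo sapiens) for antiproliferative activity, read by MTT assay, with a stated time of 96 h (on this read-out higher numbers stand for weaker inhibition and lower numbers for stronger inhibition), and every one of them returned only a limit of the assay rather than a number. Compound 1 gives > 10000 nM, which is a limit. Compound 2 gives > 10000 nM, also a limit. Compound 3 gives > 10000 nM, again a limit. All three sit at the limit of > 10000 nM in this assay, at which 3 of the 3 values shown sit.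

Compound 1 and compound 2 differ in one place, (hydrogen in place of methyl on an aromatic carbon), and the step that the two limits leave unreadable from compound 1 to compound 2 cannot be read because both values are limits. The difference between the core of compound 1 and the core of compound 3 is not broken down here.

Compound 4 `CC(C)=CCC/C(C)=C/CC/C(C)=C/CC[C@]1(C)CCc2cc(OC(=O)NS(=O)(=O)c3ccc(Cl)cc3)cc(C)c2O1` has not yet been measured. It differs from compound 3 by hydrogen in place of methyl on an aromatic carbon, the same kind of change as that from compound 1 to compound 2, but not the same: in compound 1 the methyl that leaves stands para to a large group on a six-membered ring of carbon only, whereas in compound 3 it stands on a ring that is part of a fused system of two rings, ortho to a large group, ortho to a methyl group, and meta and para to a fused ring. Since compound 3 rests at the limit of > 10000 nM in this assay, at which 3 of the 3 values shown sit, the step that the limit leaves unreadable from compound 3 to compound 4 is expected to leave compound 4 at the same limit, and compound 4 is estimated at 15000 nM.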

Compound 4, half-maximal inhibitory concentration: > 10000 nM
Compound 4 gave a limit, no number (the forecaster's own chance of this, stated with the estimate: 85%); the middle value lies beyond the limit too.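

In this assay, compound 3 and compound 4 each return only a limit and not a number, so no step between them can be read: the limit of > 10000 nM in this assay, at which 4 of the 4 values shown sit.

The compounds shown leave open how large an effect hydrogen in place of methyl on an aromatic carbon has on this activity, and where any of the four compounds truly stands beyond that limit.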